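Anilide variation on the shared core: compound 4

The source may report more compounds than this note shows. Statements on the series, on what has been measured and on what is new or still open speak of the compounds shown alone.

Going by the values given here, compound 3 `COc1ccc(NC(=O)CCC(=O)OCCCCCCSc2ccc([N+](=O)[O-])c3nonc23)cc1` gives 420 nM in an assay on isolated protein for inhibition of glutathione S-transferase P (Homo sapiens), with a stated time of 10 min (on this read-out higher numbers stand for weaker inhibition and lower numbers for stronger inhibition), the lowest number of the three measured members. Compound 1 `Cc1ccccc1NC(=O)CCC(=O)OCCCCCCSc1ccc([N+](=O)[O-])c2nonc12` gives 4100 nM and compound 2 `O=C(CCC(=O)OCCCCCCSc1ccc([N+](=O)[O-])c2nonc12)Nc1ccc(Br)cc1` gives 5090 nM. The steps of a 9.8-fold lower number from compound 1 to compound 3 (0.99 log units; beyond the scatter) and a 12-fold lower number from compound 2 to compound 3 (1.08 log units; beyond the scatter) both run toward compound 3, while a 1.2-fold higher number from compound 1 to compound 2 (0.09 log units; within the scatter) stays flat. Compound 4 `O=C(CCC(=O)OCCCCCCSc1ccc([N+](=O)[O-])c2nonc12)Nc1ccc(F)c(Cl)c1` has not yet been measured; relative to compound 3 it carries 3-chloro-4-fluorophenyl in place of 4-methoxyphenyl on an amide-type nitrogen. The step that bears most directly on this change is the one in which methoxy replaced bromo, a 12-fold lower number from compound 2 to compound 3 (1.08 log units; beyond the scatter); compound 4 moves the other way, from methoxy to a ring carrying chloro and fluoro, so the expected move is back toward the numbers shared by compound 1 and compound 2. For compound 4 the expected step is an 8.3-fold higher number from compound 3 to compound 4 (0.92 log units; beyond the scatter), toward weaker inhibition. Compound 4 is accordingly estimated at 3500 nM, with a range from 1000 nM to 12000 nM.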

Compound 4, half-maximal inhibitory concentration: 9850 nM
For compound 4 the middle estimate is 2.8-fold (0.45 log units) below the measured one, and the stated range covers the measured number.
By their numbers in this assay, from the lowest: compound 3; then compounds 1, 2 and 4 (each within the scatter of the next, the first and the last beyond it).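

In this assay, the step to 3-chloro-4-fluorophenyl on the amide-type nitrogen is large: a 23-fold higher number from compound 3 to compound 4 (1.37 log units; beyond the scatter). Set against the other rings, the result is a 1.9-fold higher number from compound 2 to compound 4 (0.29 log units; within the scatter) and a 2.4-fold higher number from compound 1 to compound 4 (0.38 log units; beyond the scatter), so a second ring bearing halogen stays level with the 4-bromophenyl of compound 2, and 4-methoxyphenyl remains the only group here with a clearly lower number. No supporting measurement bears on this result.

Still open, as far as these compounds go, is whether the low number is specific to 4-methoxyphenyl or extends to related rings such as 4-ethoxyphenyl, 4-hydroxyphenyl or 4-(dimethylamino)phenyl on the same nitrogen. From the compounds shown here alone, it is also open whether the large gap between 4-methoxyphenyl and the halogen-bearing rings persists with a shorter chain in the shared core.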